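The source may report more compounds than this note shows. Statements on the series, on what has been measured and on what is new or still open speak of the compounds shown alone.

Measured so far:
- compound 1 `O=C1C=C(NC2CCCC2)C(=O)c2c1nc1n2[C@H]2OC[C@@H](O)[C@H]2OC1` — > 8000 nM
- compound 2 `O=C1C(N2CCC2)=CC(=O)c2c1nc1n2[C@H]2OC[C@@H](O)[C@H]2OC1` — > 16000 nM

In a functional assay on MGC-803 cells (Homo sapiens) for inhibition, read by sulforhodamine B assay (a lower number here means a stronger inhibitor, a higher number a weaker inhibitor), compound 1 gives > 8000 nM, which is a limit of the assay and not a number. In this assay compound 2 gives > 16000 nM, also a limit. Within the data shown here, compound 1 thus stands only at a limit, and the single other value shown is a limit as well the limit of > 8000 nM in this assay, at which 1 of the 2 values shown sits (the limit of > 16000 nM in this assay, at which 1 of the 2 values shown sits), so no measured step between the two is available.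

Compound 3 `O=C1C=C(Nc2ccccc2)C(=O)c2c1nc1n2[C@H]2OC[C@@H](O)[C@H]2OC1` is still to be measured in this assay. It differs from compound 1 by phenyl in place of cyclopentyl on an amine nitrogen. With both neighbours at limits, no step beyond the scatter is expected in this assay in either direction; the expected step that the limit leaves unreadable from compound 1 to compound 3 is essentially none. Compound 3 is therefore expected to give about 10000 nM, within 3000 nM to 40000 nM, most likely reported again as a limit.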

Compound 3, half-maximal inhibitory concentration: 1730 nM
Estimate against measurement, compound 3: 5.8-fold (0.76 log units) above; measured number below the stated range.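

In this assay, phenyl in place of cyclopentyl on an amine nitrogen brings an at least 4.6-fold lower number from compound 1 to compound 3 (0.66 log units; beyond the scatter). This gives the series its first reading that is a number and not a limit, with compound 3 at 1730 nM, so the substituent on this nitrogen can shift the read-out. Compound 1 stands at a limit, so the step is only a minimum and its full size remains unknown: the limit of > 8000 nM in this assay, at which 1 of the 3 values shown sits.

The step swaps a five-membered non-aromatic ring for a six-membered aromatic ring at once, so the compounds shown do not separate ring size from aromatic character; a cyclohexyl group on the same nitrogen would do so. Also open, from the compounds shown here alone, is how substituents on the phenyl ring, such as a methoxy group or a chlorine atom, would affect the reading.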